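Adding a Fluorine to a Fluorinated Alcohol

The source may report more compounds than this note shows. Statements on the series, on what has been measured and on what is new or still open speak of the compounds shown alone.

The measured compounds in a physicochemical assay for lipophilicity, read by NMR; on this read-out higher numbers stand for higher lipophilicity and lower numbers for lower lipophilicity:
- compound 1, `FCCCOc1ccc2[nH]ccc2c1`, gives 2.5
- compound 2, `CC[C@H](F)[C@H](C)O`, gives 0.68
- compound 3, `OCCC(F)(F)C(F)F`, gives 0.66

Compound 3 holds the lowest of the three numbers, but compound 2 sits so close to it that the two cannot be told apart within the usual scatter of this assay. Compound 1 alone lies clearly higher, well beyond the scatter. Among the compounds with values here, none of these three compounds differs from another in a single place, so no measured step is available to guide the next comparison.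

Compound 4, `OCCC(F)(F)C(F)(F)F`, differs from compound 3 in one place: fluoro in place of hydrogen on a saturated chain carbon bound to two fluorine atoms and a saturated chain carbon. Within the data shown here, with no measured step of this kind among the compounds at hand, the expectation rests on the change alone, and a small rise in this assay is expected, a number 0.34 log units higher from compound 3 to compound 4 (beyond the scatter), just beyond the scatter. Compound 4 is therefore estimated at 1, with a range from 0.6 to 1.4.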

Compound 4, partition coefficient: 1.3
Beside the measured number, compound 4's estimate is 0.30 log units below it, within the range that was stated.
By their numbers in this assay, from the lowest: compounds 3 and 2 (each within the scatter of the next); then compound 4; then compound 1.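

Fluoro in place of hydrogen on a saturated chain carbon bound to two fluorine atoms and a saturated chain carbon is the only one-place change seen so far, and in this assay it appears as a number 0.64 log units higher from compound 3 to compound 4 (beyond the scatter) in a single measured pair. Within the data shown here, the earlier compounds offered no such pair, so this is the first direct reading of what one change does here, and its size stands clear of the usual scatter. Nothing available explains why the number moves in this direction or by this much.

This one step cannot show whether the same swap would give a similar change on a different chain carbon. It also leaves open how the change would behave on a longer chain, or with an amine or a carboxylic acid in place of the alcohol.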